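Aryl carboxylate substitution pattern in the ether-linked series

This account rests on a few compounds, and the source may have more. Where it says the series, first, only, none or still open, it means among the compounds named here.

compound 1 `Cc1c(OCCCCOc2ccc(C(=O)O)cc2F)ccc(C(=O)CC2CCCC2)c1O`: in an assay on HEK293 cells for positive allosteric modulation of metabotropic glutamate receptor 3 (Rattus norvegicus), read by thallium flux, with a stated time of 2.5 min (a lower number here means that less compound is needed, a higher number that more compound is needed for the effect), compound 1 gives > 10000 nM, a limit
compound 2 `Cc1c(OCCCCOc2ccc(C(=O)O)c(Cl)c2)ccc(C(=O)CC2CCCC2)c1O`: compound 2 gives 2250 nM
compound 3 `Cc1cc(C(=O)O)ccc1OCCCCOc1ccc(C(=O)CC2CCCC2)c(O)c1C`: compound 3 gives > 10000 nM, a limit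
compound 4 `Cc1cc(OCCCCOc2ccc(C(=O)CC3CCCC3)c(O)c2C)ccc1C(=O)O`: not yet measured

Compound 3 gives no number, only a limit; it sits at the limit of > 10000 nM in this assay, at which 2 of the 3 values shown sit. For the measured compounds named here, compound 2 is the one measured compound with a read number. The step of an at least 4.4-fold lower number from compound 1 to compound 2 (0.64 log units; beyond the scatter) is therefore known only as a bound, and so is an at least 4.4-fold higher number from compound 2 to compound 3 (0.64 log units; beyond the scatter); the step that the two limits leave unreadable from compound 1 to compound 3 cannot be sized at all.

Compound 4 differs from compound 3 by 4-carboxy-3-methylphenyl in place of 4-carboxy-2-methylphenyl on an oxygen on a saturated carbon. Going by the values given here, the steps that bear on it are those that exchanged the aryl carboxylate group on the same oxygen: an at least 4.4-fold lower number from compound 1 to compound 2 (0.64 log units; beyond the scatter) when a 4-carboxy-3-chlorophenyl replaced a 4-carboxy-2-fluorophenyl, and an at least 4.4-fold higher number from compound 2 to compound 3 (0.64 log units; beyond the scatter) when a 4-carboxy-2-methylphenyl replaced that 4-carboxy-3-chlorophenyl. Compound 4 carries a 4-carboxy-3-methylphenyl, the arrangement of compound 2 with methyl in place of chloro. The step from compound 3 to compound 4 is therefore expected to lower the number, of the order an at least 2.8-fold lower number from compound 3 to compound 4 (0.45 log units; beyond the scatter), though compound 3 sits at a limit and the size is uncertain. Compound 4 is expected to give about 3500 nM, in the range 1200 nM to 10000 nM.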

Compound 4, half-maximal effective concentration: > 10000 nM
Compound 4 was reported as a limit (the forecaster's own chance of this, stated with the estimate: 30%); middle value at least 2.8-fold (0.45 log units) away from the limit.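

In this assay, putting a methyl where the chloro stood gives an at least 4.4-fold higher number from compound 2 to compound 4 (0.64 log units; beyond the scatter). For the compounds shown here, the 4-carboxy-3-methylphenyl group therefore does not keep the read value of compound 2 even though it has the same arrangement, and the earlier compounds had not separated the arrangement from the chloro in this way; the steps that join compound 4 to compound 1 and to compound 3 lie between two limits and cannot be read, so moving the methyl shows no readable gain. Compound 2 remains the only compound in the series with a read number, and the others all stop at the same limit of the assay: the limit of > 10000 nM in this assay, at which 3 of the 4 values shown sit.

Going by these compounds, whether the read number of compound 2 depends on chloro specifically stays open, and a bromo or a trifluoromethyl group in place of that chloro would test this on the same core. Going by these compounds alone, the order among compound 1, compound 3 and compound 4 also stays open, as does whether a shorter or longer chain than the one shared here would change the picture.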